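Changing the side group on compound 1

This account rests on a few compounds, and the source may have more. Where it says the series, first, only, none or still open, it means among the compounds named here.

In a physicochemical assay for solubility, measured as kinetic solubility (a lower number here means a less soluble compound, a higher number a more soluble compound), compound 1 `CNC(=O)c1cc(C(=O)N[C@H]2CC[C@H](O)CC2)n([C@@H](C)c2cccc(Cl)c2)n1` gives >= 143 ug/mL, which is a limit and not an exact number. Compound 2 `CNC(=O)c1cc(C(=O)N[C@H]2CC[C@H](O)CC2)n([C@@H](C)c2ccc(C(F)(F)F)cc2)n1` gives >= 175 ug/mL, which is also a limit. Going by the values given here, the one measured change is a step that the two limits leave unreadable from compound 1 to compound 2, so it offers no size to build on. Compound 3 `CC[C@@H](c1ccccc1)n1nc(C(=O)NC)cc1C(=O)N[C@H]1CC[C@H](O)CC1` carries a different change: 1-phenylpropyl in place of 1-(3-chlorophenyl)ethyl on an aromatic nitrogen. With no readable step as a guide, no shift beyond the usual scatter is expected in this assay. The expected change is a step that the limit leaves unreadable from compound 1 to compound 3. Compound 3 is estimated at 150 ug/mL, within a range from 70 ug/mL to 230 ug/mL.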

Compound 3, solubility: 138 ug/mL
The estimate for compound 3 lay 1.1-fold (0.04 log units) above the measured number, and the stated range covers the measured number.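

In this assay, compound 3 gives the only exact number shown so far, 138 ug/mL, and it shows that this position on the aromatic nitrogen can carry 1-phenylpropyl. The swap gives an at least 1.0-fold lower number from compound 1 to compound 3 (0.01 log units; that floor lies within the scatter). That size is only a floor, and the true step may be larger, because compound 1 stands at a limit: the limit of >= 143 ug/mL in this assay, at which 1 of the 3 values shown sits.

The chlorine leaves and the chain lengthens in the same step, and the compounds shown do not separate the two. Also open, on these data alone, is how the number would respond to an amine or a carboxylic acid on the phenyl ring of this side group.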